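The source may hold more compounds than are shown below. What is called first, only, known or untested is meant among the compounds shown, and "the series" means these compounds.

In a functional assay on MGC-803 cells (Homo sapiens) for inhibition, read by MTT assay, with a stated time of 48 h (a lower number here means a stronger inhibitor, a higher number a weaker inhibitor), the three measured compounds are:

compound 1 `Cc1ccc(NC(=S)NC(=O)c2ccc(OCc3ccc(C(F)(F)F)cc3)cc2)cc1-c1nc2ccccc2[nH]1`: 6500 nM
compound 2 `Cc1ccc(NC(=S)NC(=O)c2ccc(OCc3ccc(F)cc3)cc2)cc1-c1nc2ccccc2[nH]1`: 2810 nM
compound 3 `Cc1ccc(NC(=O)NC(=O)c2ccc(OCc3ccccc3)cc2)cc1-c1nc2ccccc2[nH]1`: 39400 nM

Compound 3 gives the highest number of the three and is therefore the weakest inhibitor in this assay; its nearest neighbour is compound 1, and compound 2 lies furthest from it, both gaps lying beyond the scatter. The step to compound 4 `Cc1ccc(NC(=O)NC(=O)c2ccc(OCc3cccc(Cl)c3Cl)cc2)cc1-c1nc2ccccc2[nH]1` keeps everything else and makes one change: 2,3-dichlorophenyl in place of phenyl on a saturated chain carbon bound to an oxygen on an aromatic ring. Going by the values given here, only one measured step touches the same part of the molecule, a 2.3-fold lower number from compound 1 to compound 2 (0.36 log units; beyond the scatter), which swaps one group for another on the same outer ring, but in compounds whose core differs from that of compound 3, and it neither adds nor removes a halogen pair as this step does. It shows that changes on this ring move this assay only modestly. Compound 4 is therefore expected to stay near compound 3, with a step of a 1.6-fold lower number from compound 3 to compound 4 (0.20 log units; within the scatter) that is expected to be small and of uncertain direction. The estimate for compound 4 in this assay is 25000 nM, with a range from 8000 nM to 80000 nM.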

Compound 4, half-maximal inhibitory concentration: > 100000 nM
Compound 4 gave a limit, no number (the forecaster's own chance of this, stated with the estimate: 10%); at least 4.0-fold (0.60 log units) between middle value and limit.
By their numbers in this assay, from the lowest: compound 2; then compound 1; then compound 3. At a limit, above all of these: compound 4.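

Compound 4 gives > 100000 nM in this assay, which is a limit of the assay and not a number. The change to 2,3-dichlorophenyl on the shared core therefore weakens inhibition, with an at least 2.5-fold higher number from compound 3 to compound 4 (0.40 log units; beyond the scatter), so this outer ring does not accept every substitution on that core. The earlier step, a 2.3-fold lower number from compound 1 to compound 2 (0.36 log units; beyond the scatter), showed only a modest shift between two single groups on the core of compound 1, whereas this one shows a clear loss on the core of compound 3.

The compounds shown leave open whether the loss needs both chlorines, since one chlorine alone, or a methoxy group or an amine on this ring, could behave differently. They also leave open whether 2,3-dichlorobenzyl would cost as much on the core of compound 1.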